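The compounds below may be only part of what the source reports. "The series", "measured", "known", "first", "only" and "open" are said of these compounds alone.

Measured so far:
Compound 1, `CC[C@H](C)C(=O)O[C@H]1C[C@@H](C)C=C2C=C[C@H](C)[C@H](CC[C@@H](O)C[C@@H](CC(=O)NO)OC(=O)C(C)(C)C)[C@H]21`: 7200 nM
Compound 2, `CC[C@H](C)C(=O)O[C@H]1C[C@@H](C)C=C2C=C[C@H](C)[C@H](CC[C@@H](O)C[C@@H](CC(=O)NO)OC(=O)c3ccc(OC(F)(F)F)cc3)[C@H]21`: 20300 nM

In a functional assay on PC-3 cells (Homo sapiens) for inhibition, read by sulforhodamine B assay, with a stated time of 48 h (a higher number here means a weaker inhibitor, a lower number a stronger inhibitor), compound 1 gives 7200 nM, the lowest of the two numbers shown; compound 2 gives 20300 nM in this assay. Within the data shown here, the single step in hand, a 2.8-fold higher number from compound 1 to compound 2 (0.45 log units; beyond the scatter), replaces tert-butyl with an aromatic ring on the carbonyl carbon and raises the number by a modest amount.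

Compound 3, `CC[C@H](C)C(=O)O[C@H]1C[C@@H](C)C=C2C=C[C@H](C)[C@H](CC[C@@H](O)C[C@@H](CC(=O)NO)OC(=O)c3ccc([N+](=O)[O-])cc3)[C@H]21`, is not yet measured. It differs from compound 1 by 4-nitrophenyl in place of tert-butyl on a carbonyl carbon. Among the measured compounds shown here, this is the same kind of exchange as the one from compound 1 to compound 2, a tert-butyl giving way to a substituted six-membered aromatic ring, so that step is the only one bearing on it. On that basis a modest rise in this assay is expected for compound 3, of about a 2.1-fold higher number from compound 1 to compound 3 (0.32 log units; beyond the scatter). Compound 3 is therefore estimated at 15000 nM, with a range from 6000 nM to 40000 nM.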

Compound 3, half-maximal inhibitory concentration: 8200 nM
Estimate against measurement, compound 3: 1.8-fold (0.26 log units) above; the range from low to high includes it.
By their numbers in this assay, from the lowest: compounds 1 and 3 (each within the scatter of the next); then compound 2.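

In this assay, an aromatic ring on this carbonyl carbon does not by itself change the number, since 4-nitrophenyl in place of tert-butyl gives a 1.1-fold higher number from compound 1 to compound 3 (0.06 log units; within the scatter). What separates the two aromatic esters is the substituent on the ring: nitro in place of trifluoromethoxy on an aromatic carbon gives a 2.5-fold lower number from compound 2 to compound 3 (0.39 log units; beyond the scatter), so the rise seen with compound 2 goes with trifluoromethoxy and not with the ring alone. No measurement in hand explains this difference between the two substituents.

The compounds shown leave open whether an unsubstituted phenyl, or a ring carrying an amine or a carboxylic acid, would stand with compound 3 or with compound 2. They also leave open how a longer alkyl chain on this carbonyl carbon would compare with tert-butyl.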